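The source may hold more compounds than are shown below. What is called first, only, known or untested is meant among the compounds shown, and "the series" means these compounds.

In a functional assay on HL-60 cells (Homo sapiens) for inhibition, read by MTT assay, with a stated time of 72 h (on this read-out lower numbers stand for stronger inhibition and higher numbers for weaker inhibition), compound 1 (`Cc1nc(-c2ccccc2)c(C(=O)N2CCN(c3cccc(Cl)c3)CC2)o1`) gives 39.2 nM, the lower of the two numbers available. Compound 2 (`Cc1nc(-c2ccccc2)c(C(=O)N2CCN(c3cccc(Cl)c3Cl)CC2)o1`) gives 133 nM, while compound 3 (`C=C(C)c1ccc(N2CCN(C(=O)c3oc(C)nc3-c3ccccc3)CC2)cc1`) is reported as "not active" (no number reported), without a number. Compound 4 (`COc1ccc(-c2nc(C)oc2C(=O)N2CCN(c3cccc(Cl)c3)CC2)cc1`) takes compound 1 as its starting point and replaces phenyl with 4-methoxyphenyl, that is, methoxy in place of hydrogen on an aromatic carbon.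

Within the data shown here, only one measured step bears on this change, and only indirectly. a 3.4-fold higher number from compound 1 to compound 2 (0.53 log units; beyond the scatter) is a modest step beyond the scatter, in which chloro replaces hydrogen on an aromatic carbon elsewhere in the molecule. Among the measured compounds shown here, no measured compound carries methoxy or any other change at the phenyl, so the data give no direct guide. With that modest step as the only yardstick, a modest rise in this assay seems the likeliest outcome, though a fall cannot be excluded. An estimated 1.5-fold higher number from compound 1 to compound 4 (0.18 log units; within the scatter) is expected. Compound 4 is expected to give about 60 nM, with an estimated range from 15 nM to 240 nM.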

Compound 4, half-maximal inhibitory concentration: "not active" (no number reported)
The entry for compound 4 holds no number; the estimate stays without a comparison.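

In this assay, among these compounds, compound 4 is reported as "not active" (no number reported) and so gives no step from compound 1 that can be read. The compounds shown leave open what number, if any, 4-methoxyphenyl in place of phenyl would give. No measurement here speaks to a cause for this result.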